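The source may report more compounds than this note shows. Statements on the series, on what has been measured and on what is new or still open speak of the compounds shown alone.

Measured in a toxicity assay on WI-38 cells (Homo sapiens) for inhibition, read by MTT assay, with a stated time of 72 h; on this read-out lower numbers stand for stronger inhibition and higher numbers for weaker inhibition:
Compound 1 `O=C(NCc1ccc(NC(=O)c2ccc(F)cc2N2CCCC2)cc1)OCc1cccnc1`: > 100000 nM
Compound 2 `COc1ccc(N2CCCC2)c(C(=O)Nc2ccc(CNC(=O)OCc3cccnc3)cc2)c1`: 35600 nM

Compound 1 stands at the edge of what this assay can report. Its entry of > 100000 nM is a limit and not a number, as the limit of > 100000 nM in this assay, at which 1 of the 2 values shown sits, records. Compound 3 `Cc1ccc(C(=O)Nc2ccc(CNC(=O)OCc3cccnc3)cc2)c(N2CCCC2)c1` keeps the core of compound 1 and makes one change: methyl in place of fluoro on an aromatic carbon, meta to a pyrrolidin-1-yl group and para to a large group (methyl in place of fluoro on an aromatic carbon). Among the measured compounds shown here, no measured pair of compounds shows this swap alone. For the measured compounds named here, the only true number so far is that compound 2 gives 35600 nM, so a reading near that value seems a likely outcome. A reading at the limit of compound 1 seems likely as well. The expected change in this assay is small and toward stronger inhibition, estimated as an at least 1.4-fold lower number from compound 1 to compound 3 (0.15 log units; that floor lies within the scatter). For compound 3 the estimated value is 70000 nM, with an expected range from 30000 nM to 150000 nM.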

Compound 3, half-maximal inhibitory concentration: > 100000 nM
Compound 3 gave a limit, no number (the forecaster's own chance of this, stated with the estimate: 45%); middle value at least 1.4-fold (0.15 log units) from the limit.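

Compound 1 and compound 3 both end at a limit and not a number, so no step between them can be read: the limit of > 100000 nM in this assay, at which 2 of the 3 values shown sit.

The compounds shown leave open whether methyl in place of fluoro on an aromatic carbon shifts the reading in this assay at all, and by how much.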